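The compounds below may be only part of what the source reports. "The series", "measured", "known", "first", "only" and "open" are said of these compounds alone.

Compound 1 `Nc1ccccc1NC(=O)c1ccc(CNC(=O)c2cc3cccnc3[nH]2)cc1` gives > 100000 nM in a functional assay on MDA-MB-231 cells (Homo sapiens) for cytotoxicity, read by MTT assay, with a stated time of 72 h (a lower number here means a stronger inhibitor, a higher number a weaker inhibitor), which is a limit of the assay.
Compound 2 `Nc1ccccc1NC(=O)c1ccc(NC(=S)NCc2cncc(F)c2)cc1` gives 85000 nM in this assay.
Compound 3 `Nc1ccc(CNC(=O)Nc2ccc(C(=O)Nc3ccccc3N)cc2)cn1` gives > 100000 nM in this assay, which is a limit of the assay.

Among the measured compounds shown here, compound 2 thus holds the only numerical value among the three, with the other two sitting at the limit of > 100000 nM in this assay, at which 2 of the 3 values shown sit. Compound 4 `Nc1ccccc1NC(=O)c1ccc(NC(=S)NCc2cccc(Cl)c2)cc1` is not yet measured and differs from compound 2 by 3-chlorophenyl in place of 5-fluoropyridin-3-yl on a saturated chain carbon bound to an amide-type nitrogen. For the measured compounds named here, with no measured step between related compounds to lean on, the expected change is small, a step from compound 2 to compound 4 of a 1.4-fold lower number from compound 2 to compound 4 (0.15 log units; within the scatter), lying within the usual scatter. Compound 4 is therefore estimated at 60000 nM, with a range from 20000 nM to 150000 nM.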

Compound 4, half-maximal inhibitory concentration: 92000 nM
Beside the measured number, compound 4's estimate is 1.5-fold (0.19 log units) below it; measured number inside the range.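

Among the compounds shown here, this is the first step between compounds that differ in one place, and in this assay it reads a 1.1-fold higher number from compound 2 to compound 4 (0.03 log units; within the scatter). On a saturated chain carbon bound to an amide-type nitrogen, then, 3-chlorophenyl and 5-fluoropyridin-3-yl cannot be told apart, so losing the ring nitrogen and exchanging fluorine for chlorine shows no readable effect here. Both numbers lie close to the top of the range that can be read: the limit of > 100000 nM in this assay, at which 2 of the 4 values shown sit.

As far as these compounds go, whether an amine or a carboxylic acid on this ring, or a longer chain leading to it, would give a lower number stays open.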